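The source may hold more compounds than are shown below. What is called first, only, known or untested is meant among the compounds shown, and "the series" means these compounds.

Compound 1 `O=C(O)CCc1cccc(NCc2ccc(-c3ccccc3)cc2)c1`: 501 nM
Compound 2 `O=C(O)CCc1ccc(NCc2ccc3ccccc3c2)cc1`: 794 nM
Compound 3 `O=C(O)CCc1ccc(NCc2ccc(C(F)(F)F)cc2)cc1`: 2000 nM

Of the compounds shown here, three with a shared core have been tested in a functional assay for agonist activity at Free fatty acid receptor 1 (Homo sapiens); a lower number here means that less compound is needed, a higher number that more compound is needed for the effect. In this assay compound 3 gives 2000 nM, the highest number of the three. Its nearest neighbour is compound 2, which gives 794 nM, a gap that lies beyond the scatter, and the furthest is compound 1, which gives 501 nM, a gap also beyond the scatter. So compound 3 needs more material than either of the other two for the same effect. Between compound 1 and compound 2 the two numbers stand close enough that nothing can be read from their order.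

The next compound, compound 4 `O=C(O)CCc1ccc(NCc2ccc(Oc3ccccc3)cc2)cc1`, keeps the core of compound 3 and differs from it in one place: phenoxy in place of trifluoromethyl on an aromatic carbon. For the measured compounds named here, no step between two measured compounds covers a change of this kind, so the expectation leans on the spread among the three numbers above. Compound 1 and compound 2, each carrying a second aromatic ring at the far end, give the two lower numbers. On that basis the step from compound 3 to compound 4 is expected to lower the number by about a 3.2-fold lower number from compound 3 to compound 4 (0.50 log units; beyond the scatter), beyond the scatter. Compound 4 is therefore estimated at 630 nM, with a range from 200 nM to 2000 nM.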

Compound 4, half-maximal effective concentration: 195 nM
The estimate for compound 4 lay 3.2-fold (0.51 log units) above the measured number; measured number below the stated range.
By their numbers in this assay, from the lowest: compound 4; then compounds 1 and 2 (each within the scatter of the next); then compound 3.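

In this assay, for the compounds shown here, replacing trifluoromethyl with phenoxy gives a 10-fold lower number from compound 3 to compound 4 (1.01 log units; beyond the scatter), the first one-place change that can be read. It shows that this aromatic carbon, para to a large group, accepts a substituent with an added six-membered aromatic ring, and that the number responds strongly to the group placed there. The change brings in that ring and an oxygen together, so the step cannot separate their contributions, and no measurement at hand accounts for the size of the drop.

The compounds shown leave open whether the oxygen link itself matters, which a directly attached phenyl or a benzyl group at the same carbon would test, and whether a methoxy group, which keeps the oxygen without the ring, would give any of the same gain. They also leave open how far the outer ring of phenoxy accepts further groups, such as a fluorine or a nitrile, and whether the number would fall further or rise again.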